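A few compounds are considered here, and "the series" means these few. Any claim that something is new, unique, unknown or untested is made for them only; others in the source may bear on it.

In a functional assay on MDA-MB-231 cells (Homo sapiens) for inhibition, read by MTT assay, with a stated time of 48 h (a higher number here means a weaker inhibitor, a lower number a stronger inhibitor), compound 1 (`CCc1ccc(-c2nc3ccccn3c2Sc2ccccc2)cc1`) gives > 100000 nM, which is a limit and not a number. For the measured compounds named here, compound 2 (`Clc1ccc2nc(-c3ccccc3)c(Sc3ccccc3)n2c1`) gives 55800 nM, the only true number so far. Compound 3 (`Clc1ccc(-c2nc3ccccn3c2Sc2ccccc2)cc1`) has chloro in place of ethyl on an aromatic carbon, para to a large group, the change being 4-ethylphenyl to 4-chlorophenyl: chloro in place of ethyl on an aromatic carbon. Going by the values given here, no measured step sizes this change, so compound 2 at 55800 nM is the sole guide. The estimated step of an at least 1.6-fold lower number from compound 1 to compound 3 (0.22 log units; that floor lies within the scatter) is modest, towards stronger inhibition, and loose: its starting point is only a limit. For compound 3, the expected value is 60000 nM, with an estimated range of 25000 nM to 120000 nM.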

Compound 3, half-maximal inhibitory concentration: 24500 nM
Beside the measured number, compound 3's estimate is 2.4-fold (0.39 log units) above it; measured number outside the range, below it.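

In this assay, for the compounds shown here, chloro in place of ethyl on an aromatic carbon, para to a large group, gives an at least 4.0-fold lower number from compound 1 to compound 3 (0.61 log units; beyond the scatter), the first step that can be sized and one that lies beyond the scatter. This position on the 4-substituted phenyl therefore responds to the choice of group, with chloro giving the stronger inhibition. Compound 1 stands at a limit and not a number, so the step is only a floor: the limit of > 100000 nM in this assay, at which 1 of the 3 values shown sits.

Going by these compounds, its true size remains open. So does the outcome with a methoxy group, an amine or a carboxylic acid at this position, and one step sets no trend.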